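Sulfonyl group replacement in a sulfonamide antiproliferative series

This account rests on a few compounds, and the source may have more. Where it says the series, first, only, none or still open, it means among the compounds named here.

Measured compounds:
compound 1 `Cc1ccc(S(=O)(=O)N2CCC(N3CCC(C)CC3)CC2)cc1C`: 24 nM
compound 2 `CC1CCCN(C2CCN(S(=O)(=O)c3ccc(OC(F)F)cc3)CC2)C1`: 105 nM
compound 3 `Cc1cc(C)c(S(=O)(=O)N2CCC(N3CCC(Cc4ccc(F)cc4)CC3)CC2)c(C)c1`: 18 nM

In a functional assay on DLD-1 cells (Homo sapiens) for antiproliferative activity, read by CellTiter-Glo, with a stated time of 72 h (a lower number here means a stronger inhibitor, a higher number a weaker inhibitor), compound 1 gives 24 nM. Compound 3 gives 18 nM, and the two lie within the scatter of each other. Compound 2 gives 105 nM, a higher number that lies beyond the scatter of compound 1; compound 1 thus stands second highest of the three, close to compound 3 and well apart from compound 2. Compound 4 `CC1CCN(C2CCN(S(=O)(=O)c3cn(C)cn3)CC2)CC1` differs from compound 1 at the sulfonyl sulfur: 1-methyl-1H-imidazol-4-yl in place of 3,4-dimethylphenyl on a sulfonyl sulfur. Among the measured compounds shown here, no step between measured compounds isolates a change of this kind. For the measured compounds named here, both compounds with the lower numbers carry a methyl-substituted phenyl on that sulfur, while the one compound with the higher number carries a phenyl bearing difluoromethoxy; the change in compound 4 goes further than any of these. The expectation for compound 4 is a loss of potency beyond the scatter, with the estimated step of a 4.6-fold higher number from compound 1 to compound 4 (0.66 log units; beyond the scatter). For compound 4 the estimate is 110 nM, in the range 30 nM to 400 nM.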

Compound 4, half-maximal inhibitory concentration: > 5000 nM
Compound 4: a limit, no number; the forecaster's own chance of this, stated with the estimate: 5%; middle value at least 45-fold (1.65 log units) from the limit.
By their numbers in this assay, from the lowest: compounds 3 and 1 (each within the scatter of the next); then compound 2. At a limit, above all of these: compound 4.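

In this assay, 1-methyl-1H-imidazol-4-yl in place of 3,4-dimethylphenyl on a sulfonyl sulfur gives an at least 200-fold higher number from compound 1 to compound 4 (2.31 log units; beyond the scatter). Going by these compounds, for compound 4 the reading > 5000 nM is a limit of the assay and not a number, so the full size of the step stays unknown: the limit of > 5000 nM in this assay, at which 1 of the 4 values shown sits. Compound 1, compound 2 and compound 3 all carry a substituted phenyl on that sulfur and all give a measured number, whereas this change shows that the group on the sulfur can take the series out of the measurable range.

Which part of the change carries the loss stays open: the five-membered aromatic ring, its 2 hetero atoms, or the loss of the dimethylphenyl itself. A pyridyl or a thienyl group on the same sulfur would separate ring size from ring nitrogen.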